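The compounds below may be only part of what the source reports. "The series", "measured", "known", "first", "only" and "open" are said of these compounds alone.

Measured compounds in an assay on isolated protein (urine) for inhibition of Myeloperoxidase (Homo sapiens), with a stated time of 5 min; on this read-out higher numbers stand for weaker inhibition and lower numbers for stronger inhibition:
- compound 1 `CCCc1c[nH]c2ccc(F)cc12`: > 100 nM
- compound 2 `NC(=O)CCc1c[nH]c2c(F)cccc12`: 271 nM
- compound 3 `NCC(N)CCc1c[nH]c2ccc(F)cc12`: 60 nM

Compound 1 stands at a limit in this assay: the value > 100 nM is a limit of the assay and not a number, the only such case among the three (the limit of > 100 nM in this assay, at which 1 of the 3 values shown sits). Compound 3 and compound 2 each give a number in this assay, and for the pair compound 2 and compound 3 no single-place step is given, so only their two values are shown.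

Compound 4 `N#CSCCCc1c[nH]c2ccc(F)cc12` differs from compound 1 in one place: cyanosulfanyl in place of hydrogen on a saturated chain carbon, three bonds along the chain from an aromatic carbon. Among the compounds with values here, the one measured step that leaves compound 1 is an at least 1.6-fold lower number from compound 1 to compound 3 (0.22 log units; that floor lies within the scatter), and it concerns a different group at a different chain carbon, so it does not bear directly on the change to compound 4. Within the data shown here, no measured pair shows the effect of a cyanosulfanyl group anywhere. Among the measured compounds shown here, with compound 1 known only as a limit and no matching step, the step from compound 1 to compound 4 is expected to be a step that the limit leaves unreadable from compound 1 to compound 4, that is, nothing clearly beyond the scatter, with a real chance that compound 4 again returns only a limit.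

Compound 4 is therefore expected to give 200 nM in this assay, estimated between 60 nM and 1000 nM.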

Compound 4, half-maximal inhibitory concentration: 5 nM
Compound 4: middle estimate off by 40-fold (1.60 log units), on the high side; measured number outside the range, below it.
By their numbers in this assay, from the lowest: compound 4; then compound 3; then compound 2.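

In this assay, cyanosulfanyl in place of hydrogen on a saturated chain carbon, three bonds along the chain from an aromatic carbon, gives an at least 20-fold lower number from compound 1 to compound 4 (1.30 log units; beyond the scatter), whereas the earlier change on this chain gave an at least 1.6-fold lower number from compound 1 to compound 3 (0.22 log units; that floor lies within the scatter). On these data alone, compound 1 gives > 100 nM, which is a limit of the assay and not a number, so the full size of the step from it stays unknown: the limit of > 100 nM in this assay, at which 1 of the 4 values shown sits. The comparison with the diamine adds a 12-fold lower number from compound 3 to compound 4 (1.08 log units; beyond the scatter), which shows that this chain position can carry a much stronger result in this assay than either earlier compound on the same core, and that the result does not depend on keeping the 1,2-diaminoethyl group.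

As far as these compounds go, whether the gain belongs to the whole cyanosulfanyl group, to its sulfur or to its nitrile remains open, and a thiol, a methylsulfanyl group or a plain nitrile on the same chain carbon would be needed to separate these. Also open, from the compounds shown here alone, is how the group behaves on a shorter or longer chain, since the series holds it at a single chain length.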